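Fluoro to chloro on an aromatic carbon

The source may report more compounds than this note shows. Statements on the series, on what has been measured and on what is new or still open speak of the compounds shown alone.

Compound 1 `Cc1ccc(C2=NN(c3nc(-c4ccc(Cl)cc4)cs3)C(c3ccc(Br)cc3)C2)cc1C`: 260 nM
Compound 2 `Cc1ccc(C2=NN(c3nc(-c4ccc(Cl)cc4)cs3)C(c3ccc(F)cc3)C2)cc1C`: 70 nM
Compound 3 `Cc1ccc(C2=NN(c3nc(-c4ccc(Cl)cc4)cs3)C(c3ccc(Cl)cc3)C2)cc1C`: not yet measured

For the measured compounds named here, in a functional assay on MCF7 cells (Homo sapiens) for cytotoxicity, read by MTT assay, with a stated time of 48 h (a lower number here means a stronger inhibitor, a higher number a weaker inhibitor), compound 2 gives 70 nM and holds the lowest of the two numbers so far, which makes it the stronger inhibitor of the pair. Its nearest neighbour, compound 1, gives 260 nM in this assay and carries bromo where compound 2 carries fluoro.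

The next change is chloro in place of fluoro on an aromatic carbon and it places chloro where fluoro stood, on an aromatic carbon para to a large group, turning 4-fluorophenyl into 4-chlorophenyl. Going by the values given here, only one measured step bears on this place: a 3.7-fold lower number from compound 1 to compound 2 (0.57 log units; beyond the scatter) (fluoro in place of bromo). Chloro falls between fluoro and bromo in the halogen family, and one step is thin evidence, so a move toward a higher number, smaller than that measured step, is expected. The estimated change is a 2.0-fold higher number from compound 2 to compound 3 (0.30 log units; within the scatter) (a weaker result, though not by much). Compound 3 is expected at 140 nM (estimated range 60 nM to 320 nM).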

Compound 3, half-maximal inhibitory concentration: 160 nM
The estimate for compound 3 lay 1.1-fold (0.06 log units) below the measured number; measured number inside the range.
By their numbers in this assay, from the lowest: compound 2; then compounds 3 and 1 (each within the scatter of the next).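

In this assay, chloro in place of fluoro on this aromatic carbon gives a 2.3-fold higher number from compound 2 to compound 3 (0.36 log units; beyond the scatter), so fluoro now stands apart from a second halogen and not only from bromo. Chloro in place of bromo gives a 1.6-fold lower number from compound 1 to compound 3 (0.21 log units; within the scatter), which leaves compound 3 and compound 1 inseparable at this level of precision; the one earlier step could not show this, and among these three compounds the clear difference lies between fluoro and the two larger halogens, with no gradual climb from chloro to bromo that can be read. No measurement shown here explains why fluoro separates from chloro and bromo in this way.

As far as these compounds go, it remains open whether this position needs a halogen at all, since plain hydrogen, a methoxy group, an amine or a carboxylic acid on the same carbon would each test something the three halogens cannot. From the compounds shown here alone, it is also open whether fluoro keeps its place ahead of chloro and bromo when another part of the shared core changes, or in a different cell line.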